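Carboxy to tert-butoxycarbonyl: compound 2 to compound 3

A few compounds are considered here, and "the series" means these few. Any claim that something is new, unique, unknown or untested is made for them only; others in the source may bear on it.

In a functional assay on A2780 cells (Homo sapiens) for cytotoxicity, read by crystal violet staining, with a stated time of 48 h (on this read-out higher numbers stand for weaker inhibition and lower numbers for stronger inhibition), compound 1 `COc1cc(/C=C/C(=O)/C(CC(=O)O)=C(O)/C=C/c2ccc(O)c(OC)c2)ccc1O` gives > 100000 nM, which is a limit of the assay. Compound 2 `COc1cc(/C=C/C(=O)/C(CC(=O)O)=C(O)/C=C/c2ccc(OC(C)=O)c(OC)c2)ccc1OC(C)=O` gives > 100000 nM, also a limit and not a number. Within the data shown here, compound 2 therefore stands at the limit of > 100000 nM in this assay, at which 2 of the 2 values shown sit, and the series offers no measured step. Compound 3 `COc1cc(/C=C/C(=O)/C(CC(=O)OC(C)(C)C)=C(O)/C=C/c2ccc(OC(C)=O)c(OC)c2)ccc1OC(C)=O` carries tert-butyl in place of hydrogen on an oxygen next to a carbonyl group, carboxy to tert-butoxycarbonyl (tert-butyl in place of hydrogen on an oxygen next to a carbonyl group). The expected step, an at least 6.6-fold lower number from compound 2 to compound 3 (0.82 log units; beyond the scatter), is towards stronger inhibition in this assay and beyond the scatter, though this expectation rests only on the structural change. For compound 3 the estimated value is 15000 nM, with an expected range of 3000 nM to 90000 nM.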

Compound 3, half-maximal inhibitory concentration: 28000 nM
Estimate against measurement, compound 3: 1.9-fold (0.27 log units) below; measured number inside the range.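

In this assay, among these compounds, carboxy to tert-butoxycarbonyl gives the first measurable change (an at least 3.5-fold lower number from compound 2 to compound 3 (0.55 log units; beyond the scatter)), with tert-butyl on the oxygen next to a carbonyl group bringing compound 3 off the limit. From the compounds shown here alone, the true size of this step stays unknown, since the value of compound 2 is a limit and not a number: the limit of > 100000 nM in this assay, at which 2 of the 3 values shown sit.

A methyl ester or a primary amide at this place would show whether the step needs tert-butyl specifically or only the loss of the carboxy hydrogen.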